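Lengthening the amine-bearing chain: from compound 2 to compound 3

This account rests on a few compounds, and the source may have more. Where it says the series, first, only, none or still open, it means among the compounds named here.

Measured so far:
- compound 1 `NCC#CCN(Cc1nc2ccccc2[nH]1)C1CCCc2cccnc21` gives 973 nM in a functional assay on CEM-CCRF cells for antagonist activity at C-X-C chemokine receptor type 4 (Homo sapiens), read by calcium flux; on this read-out lower numbers stand for stronger inhibition and higher numbers for weaker inhibition
- compound 2 `NCCN(Cc1nc2ccccc2[nH]1)C1CCCc2cccnc21` gives 1370 nM in this assay

Among the compounds with values here, compound 2 holds the higher of the two numbers measured so far, yet its only neighbour, compound 1, sits so close that the two cannot be told apart: a 1.4-fold higher number from compound 1 to compound 2 (0.15 log units; within the scatter). The two share one core and differ only in the chain that carries the free amine.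

Compound 3 `NCCCCCN(Cc1nc2ccccc2[nH]1)C1CCCc2cccnc21` has not yet been tested. Its change from compound 2 is 3-aminopropyl in place of amino on a saturated chain carbon, two bonds along the chain from an amine nitrogen. Read one bond further out, the chain grows from 2-aminoethyl to 5-aminopentyl, so the free amine moves further away from the core.

Within the data shown here, the one measured step that speaks to this also altered the length and make-up of that same chain, and it stayed within the scatter. Among the measured compounds shown here, there is no measured example of a chain as long as that of compound 3, so a large move is not ruled out, but nothing in hand points one way or the other. The expected step in this assay is therefore a 1.1-fold lower number from compound 2 to compound 3 (0.06 log units; within the scatter). For compound 3 the estimated value is 1200 nM, with a range from 350 nM to 4500 nM.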

Compound 3, half-maximal inhibitory concentration: 514 nM
Estimate against measurement, compound 3: 2.3-fold (0.37 log units) above, within the range that was stated.
By their numbers in this assay, from the lowest: compounds 3, 1 and 2 (each within the scatter of the next, the first and the last beyond it).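

In this assay, within the data shown here, the change from 2-aminoethyl to 5-aminopentyl gives the first step at this position that lies beyond the scatter, a 2.7-fold lower number from compound 2 to compound 3 (0.43 log units; beyond the scatter), so the length of the saturated chain carrying the free amine can show up on this read-out, though the effect here is modest. The other comparison has a different outcome: with 4-aminobutyl in place of 3-aminoprop-1-yn-1-yl, the step is a 1.9-fold lower number from compound 1 to compound 3 (0.28 log units; within the scatter), which lies within the scatter, so these two chains cannot be told apart and a longer saturated chain cannot be ranked above the chain of compound 1. No independent measurement is available to explain why the longer chain in compound 3 gives the lower number than the chain in compound 2.

Going by these compounds, with only these chains in hand, it stays open whether a longer chain still, such as 6-aminohexyl, would lower the number further or raise it again. On these data alone, it is also open whether the amine at the end of the chain matters at all, which a hydroxyl or a carboxylic acid in its place would help to test.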